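Swapping a methoxyphenyl for thiophenyl on an aryl core

A few compounds are considered here, and "the series" means these few. Any claim that something is new, unique, unknown or untested is made for them only; others in the source may bear on it.

Compound 2 `COc1ccc(-c2cn3ccnc3c(-c3ccc4ncn(C5CCCCC5)c4c3)n2)cc1` sits at the top of the three measured numbers in a functional assay on HL-60 cells (Homo sapiens) for inhibition, read by sulforhodamine B assay, with a stated time of 48 h, tested at 10 uM (on this read-out lower numbers stand for less inhibition and higher numbers for more inhibition at the one concentration tested (going by the name of the read-out)), giving 98.6%. Compound 1 `Brc1cn2ccnc2c(-c2ccc3ncn(C4CCCCC4)c3c2)n1` gives 18% and compound 3 `Brc1ccc(-c2cn3ccnc3c(-c3ccc4ncn(C5CCCCC5)c4c3)n2)cc1` gives 23.2%, and the steps of a number 80.6 percentage points higher from compound 1 to compound 2 (beyond the scatter) and a number 75.4 percentage points lower from compound 2 to compound 3 (beyond the scatter) show how much of compound 2's activity rests on the 4-methoxyphenyl group. Compound 4 `c1csc(-c2cn3ccnc3c(-c3ccc4ncn(C5CCCCC5)c4c3)n2)c1` differs from compound 2 by thiophen-2-yl in place of 4-methoxyphenyl on an aromatic carbon. The thiophen-2-yl group keeps an aromatic ring at this place but loses the methoxy whose removal, in the step from compound 2 to compound 3, cut inhibition sharply; the step from compound 1 to compound 3 shows that an unadorned ring adds little. A clear fall is therefore expected, a number 58.6 percentage points lower from compound 2 to compound 4 (beyond the scatter), putting compound 4 at an estimated 40%, between 15% and 85%.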

Compound 4, a percentage reported as inhibition, at one concentration (the size of the read-out at that concentration, not a potency): 26.6%
Compound 4: the middle estimate sits 13.4 percentage points above what was measured; the range from low to high includes it.
By their numbers in this assay, from the lowest: compounds 1, 3 and 4 (each within the scatter of the next); then compound 2.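

Putting thiophen-2-yl in place of 4-methoxyphenyl gives a number 72 percentage points lower from compound 2 to compound 4 (beyond the scatter), so an aromatic ring alone at this place does not preserve the activity of the methoxy-bearing compound. Among these compounds, the other two steps, a number 3.4 percentage points higher from compound 3 to compound 4 (within the scatter) and a number 8.6 percentage points higher from compound 1 to compound 4 (within the scatter), show that thiophen-2-yl, 4-bromophenyl and bromo cannot be told apart here, leaving 4-methoxyphenyl as the only group of the four that stands out. Nothing measured here explains why this group stands out.

From the compounds shown here alone, it remains open how specific the methoxy is. A phenyl ring carrying a hydroxyl, an amine or a longer ether chain could show whether other groups at this place restore inhibition.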